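This account rests on a few compounds, and the source may have more. Where it says the series, first, only, none or still open, it means among the compounds named here.

Measured compounds:
- compound 1, `Cc1n[nH]c2ccc(-c3nc4cnc(N5CCN(C)CC5)cn4c3Nc3ccc(F)cc3)cc12`: 32300 nM
- compound 2, `Cc1n[nH]c2ccc(-c3nc4cnc(N5CCN(C)CC5)cn4c3Nc3ccc(I)cc3)cc12`: "not determined" (no result reported)
- compound 3, `Cc1ccc(C)c(Nc2c(-c3ccc4[nH]nc(C)c4c3)nc3cnc(N4CCN(C)CC4)cn23)c1`: "not determined" (no result reported)

In a functional assay on MV4-11 cells (Homo sapiens) for inhibition, with a stated time of 120 h (on this read-out higher numbers stand for weaker inhibition and lower numbers for stronger inhibition), compound 3 has no number of its own and is reported as "not determined" (no result reported); compound 2 likewise stands without a number, reported as "not determined" (no result reported), so only compound 1 offers a value, and that value points to weak inhibition. Compound 4, `Cc1n[nH]c2ccc(-c3nc4cnc(N5CCN(C)CC5)cn4c3Nc3ccc(F)c(Cl)c3)cc12`, differs from compound 3 by 3-chloro-4-fluorophenyl in place of 2,5-dimethylphenyl on a nitrogen on an aromatic ring. Within the data shown here, with no step between measured compounds available, the size and direction of this change cannot be read from the data. The closest measured comparison is compound 1, which shares the shared core with compound 4. In this assay compound 1 gives 32300 nM. On that basis compound 4 is expected to land in the same weak range, with compound 4 estimated at 20000 nM and a plausible span from 4000 nM to 90000 nM.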

Compound 4, half-maximal inhibitory concentration: 2850 nM
Beside the measured number, compound 4's estimate is 7.0-fold (0.85 log units) above it, outside the stated range (below it).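

In this assay, chloro in place of hydrogen on an aromatic carbon of the phenyl group gives an 11-fold lower number from compound 1 to compound 4 (1.05 log units; beyond the scatter) and so shows that the number at this position can move well beyond the scatter with a single substitution, which one earlier value could not show. Steps involving compound 2 or compound 3 cannot be read, as neither has a number. Nothing available explains the size of this step.

Still open, as far as these compounds go, is how a methoxy group or an amine on this ring would compare. Also open, from the compounds shown here alone, is whether chloro alone, without the fluoro, would give a similar number.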